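Working notes on the series: from compound 1 to compound 4

The compounds below may be only part of what the source reports. "The series", "measured", "known", "first", "only" and "open" are said of these compounds alone.

Measured compounds:
- compound 1, `Cc1cccc(-c2nc(CNc3ccc(C(=O)NO)cc3)n(-c3ccccc3)n2)c1`: 8710 nM
- compound 2, `O=C(NO)c1ccc(NCc2nc(-c3cccs3)nn2-c2ccc(O)cc2)cc1`: reported only as a limit, > 20000 nM
- compound 3, `O=C(NO)c1ccc(NCc2nc(-c3ccccc3)nn2-c2ccc(Br)cc2)cc1`: 9300 nM

All three were run in a functional assay on MGC-803 cells (Homo sapiens) for antiproliferative activity, read by MTT assay, with a stated time of 72 h; a lower number here means a stronger inhibitor, a higher number a weaker inhibitor. Compound 1 gives 8710 nM and compound 3 gives 9300 nM; the two numbers sit within the usual scatter of each other, so no order between them is claimed. Compound 2 is reported only as a limit, > 20000 nM, which is the case for one of the three values shown (the limit of > 20000 nM in this assay, at which 1 of the 3 values shown sits).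

Compound 4, `O=C(NO)c1ccc(NCc2nc(-c3cc4ccccc4s3)nn2-c2ccccc2)cc1`, has not yet been measured in this assay. It differs from compound 1 in one place: 1-benzothiophen-2-yl in place of 3-methylphenyl on an aromatic carbon. Within the data shown here, no measured pair in the set shows this change, so its size must be expected rather than read. With only compound 1 as the nearest anchor at 8710 nM, the working expectation is that the change leaves the number near that of compound 1, with at most a small step in either direction, most likely not beyond the scatter.

On that basis compound 4 is estimated at 7000 nM, with a range of 2500 nM to 20000 nM, corresponding to an expected step of a 1.2-fold lower number from compound 1 to compound 4 (0.09 log units; within the scatter).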

Compound 4, half-maximal inhibitory concentration: 6110 nM
For compound 4 the middle estimate is 1.1-fold (0.06 log units) above the measured one; the range from low to high includes it.
By their numbers in this assay, from the lowest: compounds 4, 1 and 3 (each within the scatter of the next). At a limit, above all of these: compound 2.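

In this assay, among these compounds, putting 1-benzothiophen-2-yl in place of 3-methylphenyl gives a 1.4-fold lower number from compound 1 to compound 4 (0.15 log units; within the scatter), the first step that changes only one place, since the earlier compounds differ from one another in more than one place. This aromatic carbon of the five-membered aromatic ring with 3 nitrogen therefore takes a group of 9 heavy atoms, including a sulfur and a second aromatic ring, in place of one of 7 carbon atoms, with no change that can be told from the scatter. Nothing in the data on hand gives a reason for this outcome.

On these data alone, whether the same position keeps its number with a non-aromatic group, such as an amine, a carboxylic acid or a longer alkyl chain, remains open, as does whether the 1-benzothiophen-2-yl group gives a similar step when the phenyl group on the ring nitrogen carries a bromine or a hydroxyl group. Compound 2 is reported only as a limit, > 20000 nM, and it differs from each of the other compounds in more than one place, so it gives no readable step at this position.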